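Phenyl for (cyclopropylmethoxy)methyl next to the ring oxygen

A few compounds are considered here, and "the series" means these few. Any claim that something is new, unique, unknown or untested is made for them only; others in the source may bear on it.

Measured compounds:
compound 1 `O/N=C(/Nc1cccc(F)c1)c1ccc2oc(COCC3CC3)cc2c1` — 8000 nM
compound 2 `O/N=C(/Nc1cccc(Br)c1)c1ccc2oc(COCC3CC3)cc2c1` — 3200 nM

Notes on the series. In an assay on tissue (HeLa cells) for inhibition of Indoleamine 2,3-dioxygenase 1 (Homo sapiens), read by spectrophotometry (a lower number here means a stronger inhibitor, a higher number a weaker inhibitor), compound 1 gives 8000 nM, and compound 2 gives 3200 nM. Within the data shown here, the one measured step is a 2.5-fold lower number from compound 1 to compound 2 (0.40 log units; beyond the scatter), bromo in place of fluoro on an aromatic carbon. Compound 2 therefore stands at the lowest of the two numbers, with compound 1 as its nearest neighbour.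

Compound 3 `O/N=C(/Nc1cccc(Br)c1)c1ccc2oc(-c3ccccc3)cc2c1` is the next case. The change from compound 2 is phenyl in place of (cyclopropylmethoxy)methyl on an aromatic carbon. No measured step bears on this part of the shared core: the single step shown concerns the halogen on the other aromatic ring and leaves the group next to the ring oxygen untouched. There is no basis for expecting a step in either direction beyond the scatter, so the estimate for compound 3 is held near the value of compound 2 with a wide range: compound 3 is expected at 3200 nM, between 800 nM and 13000 nM, corresponding to the expected step of no change at the digits printed from compound 2 to compound 3 (within the scatter).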

Compound 3, half-maximal inhibitory concentration: 8600 nM
Compound 3: the middle estimate sits 2.7-fold (0.43 log units) below what was measured; low and high end bracket the measured number.
By their numbers in this assay, from the lowest: compound 2; then compounds 1 and 3 (each within the scatter of the next).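

In this assay the group next to the ring oxygen now has a reading of its own: the step is a 2.7-fold higher number from compound 2 to compound 3 (0.43 log units; beyond the scatter) and shows that this place on the shared core responds to what it carries, so its substituent cannot be treated as a neutral handle. With the bromo group held fixed, (cyclopropylmethoxy)methyl gives the lower number of the two groups, even though both have 6 heavy atoms, which means that size counted in heavy atoms alone does not settle the reading here. The exchange alters the ring type and removes a hydrogen-bond acceptor at once, and nothing at hand separates these two differences or accounts for the step.

Open, as far as these compounds go, is how a methyl group, a pyridine ring or a longer ether chain would read at this place, and whether an amine or a carboxylic acid on such a chain would move the number in either direction. Also open, from the compounds shown here alone, is whether the step from fluoro to bromo on the other aromatic ring holds when phenyl stands next to the ring oxygen.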